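The compounds below may be only part of what the source reports. "The series", "measured", "known", "first", "only" and "open" are said of these compounds alone.

Compound 3, with the structure `CCCCc1cn(C(c2ccccc2)c2cc3cc(Br)ccc3nc2OC)nn1`, gives 5.54% in an ADME assay on PC-3 cells (Homo sapiens) for cytotoxicity, read by sulforhodamine B assay, with a stated time of 48 h, tested at 10 uM; on this read-out lower numbers stand for less inhibition and higher numbers for more inhibition at the one concentration tested (going by the name of the read-out). On the numbers at hand this is the highest of three, yet both neighbours lie within the scatter: compound 1, `CCCCCCCc1cn(C(c2ccccc2)c2cc3cc(Br)ccc3nc2OC)nn1`, gives 4.42%, and compound 2, `CCCCCCc1cn(C(c2ccccc2)c2cc3cc(Br)ccc3nc2OC)nn1`, gives 2.32%. The steps between them are small: a number 1.1 percentage points higher from compound 1 to compound 3 (within the scatter), a number 3.2 percentage points higher from compound 2 to compound 3 (within the scatter) and a number 2.1 percentage points lower from compound 1 to compound 2 (within the scatter), each within the scatter. Compound 4, `CCCCCCCCc1cn(C(c2ccccc2)c2cc3cc(Br)ccc3nc2OC)nn1`, differs from compound 3 by butyl in place of hydrogen on a saturated chain carbon, four bonds along the chain from an aromatic carbon. For the measured compounds named here, the steps that bear on this change are those altering the same saturated chain at the same place, hydrogen in place of propyl from compound 1 to compound 3 and hydrogen in place of ethyl from compound 2 to compound 3; both were within the scatter, so in this assay no step beyond the scatter is expected from lengthening the chain once more. The step of a number 1 percentage points lower from compound 3 to compound 4 (within the scatter) is therefore expected to stay within the scatter. Compound 4 is expected to give 4.5%, with a range from 0% to 12%.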

Compound 4, a percentage reported as inhibition, at one concentration (the size of the read-out at that concentration, not a potency): 2.27%
Compound 4: middle estimate off by 2.2 percentage points, on the high side, and the stated range covers the measured number.
By their numbers in this assay, from the lowest: compounds 4, 2, 1 and 3 (each within the scatter of the next).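

In this assay the longest chain shown gives the same picture as the shorter ones, with a number 3.3 percentage points lower from compound 3 to compound 4 (within the scatter) as the step for butyl in place of hydrogen, alongside a number 0.1 percentage points lower from compound 2 to compound 4 (within the scatter) and a number 2.2 percentage points lower from compound 1 to compound 4 (within the scatter) as the steps from the two other chains. All the steps among the four compounds now lie within the scatter, so lengthening the chain further at this position adds no readable difference, and no order by chain length can be drawn from them. Nothing available on these compounds speaks to why the chain makes no readable difference here.

The compounds shown leave open whether a chain ending in an amine or a carboxylic acid would step beyond the scatter at this position. They also leave open whether a much shorter chain, such as methyl or ethyl, would do so.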